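Carbonyl substituent swap across two related compounds

This account rests on a few compounds, and the source may have more. Where it says the series, first, only, none or still open, it means among the compounds named here.

Compound 1 `COC(=O)CC(=O)N1N=C(c2ccc(N3CCN(C)CC3)cc2)CC1c1ccc(N(C)C)cc1` and compound 3 `COC(=O)CC(=O)N1N=C(c2ccc(-n3cncn3)cc2)CC1c1ccc(N(C)C)cc1` share most of their structure; their cores differ by 1H-1,2,4-triazol-1-yl in place of 4-methylpiperazin-1-yl on an aromatic carbon. In a functional assay on NCI-H1975 cells (Homo sapiens) for inhibition, read by sulforhodamine B assay, tested at 10 uM (on this read-out lower numbers stand for less inhibition and higher numbers for more inhibition at the one concentration tested (going by the name of the read-out)), compound 1 gives -2.2% and compound 3 gives 1.5%, the step being a number 3.7 percentage points higher from compound 1 to compound 3 (within the scatter). Compound 2 `CN1CCN(c2ccc(C3=NN(C(=O)c4ccc(F)cc4)C(c4ccc(N(C)C)cc4)C3)cc2)CC1` carries the change 4-fluorophenyl in place of (methoxycarbonyl)methyl on a carbonyl carbon relative to compound 1; in this assay compound 2 gives 32.2%, the step being a number 34.4 percentage points higher from compound 1 to compound 2 (beyond the scatter). Compound 4 `CN(C)c1ccc(C2CC(c3ccc(-n4cncn4)cc3)=NN2C(=O)c2ccc(F)cc2)cc1` bears the same change relative to compound 3, namely (4-fluorophenyl in place of (methoxycarbonyl)methyl on a carbonyl carbon), and the place is described in the same words. Among the compounds with values here, since compound 1 and compound 3 sit within the scatter of each other, a step of similar size is expected in this assay, a number 33.5 percentage points higher from compound 3 to compound 4 (beyond the scatter), resting on the single earlier instance a number 34.4 percentage points higher from compound 1 to compound 2 (beyond the scatter). Compound 4 is therefore estimated at 35%, between 15% and 55%.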

Compound 4, a percentage reported as inhibition, at one concentration (the size of the read-out at that concentration, not a potency): -1.1%
The estimate for compound 4 lay 36.1 percentage points above the measured number; measured number outside the range, below it.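

In this assay, 4-fluorophenyl in place of (methoxycarbonyl)methyl does not carry from one core to the other, the new case giving a number 2.6 percentage points lower from compound 3 to compound 4 (within the scatter): the same change on two cores in this assay, a number 34.4 percentage points higher (beyond the scatter) from compound 1 to compound 2 and a number 2.6 percentage points lower (within the scatter) from compound 3 to compound 4, 37 percentage points apart, beyond the scatter of two such steps. The aromatic substituent swap is just as dependent on its surroundings, with 1H-1,2,4-triazol-1-yl in place of 4-methylpiperazin-1-yl giving a number 33.3 percentage points lower from compound 2 to compound 4 (beyond the scatter): the same change on two cores in this assay, a number 3.7 percentage points higher (within the scatter) from compound 1 to compound 3 and a number 33.3 percentage points lower (beyond the scatter) from compound 2 to compound 4, 37 percentage points apart, beyond the scatter of two such steps. Among these compounds, the higher number appears only where 4-fluorophenyl and 4-methylpiperazin-1-yl occur together, in compound 2, but this single set of four compounds does not show why, or whether the pairing holds elsewhere in the series.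

Still open, from the compounds shown here alone, is whether morpholin-4-yl or piperidin-1-yl could stand in for 4-methylpiperazin-1-yl alongside 4-fluorophenyl. Also open, going by these compounds, is whether a 4-chlorophenyl or unsubstituted phenyl group on the carbonyl carbon would behave like 4-fluorophenyl.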